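The compounds below may be only part of what the source reports. "The series", "measured", "known", "first", "only" and "open" are said of these compounds alone.

Compound 1 `O=C(NO)c1ccc(-c2cn([C@H]3C[C@@H](CO)N(Cc4ccccc4)C3)nn2)cc1`: < 10%
Compound 2 `O=C(NO)c1ccc(-c2cn([C@H]3C[C@@H](CO)N(CCCc4ccccc4)C3)nn2)cc1`: < 10%
Compound 3 `O=C(/C=C/c1cn([C@H]2C[C@H](C(=O)O)N(CCCc3ccccc3)C2)nn1)NO`: 20%

Of the compounds shown here, three have been tested in an assay on Sf9 cells for inhibition of histone deacetylase 11 (Homo sapiens), read by fluorescence, tested at 0.5 uM; on this read-out higher numbers stand for more inhibition at the one concentration tested (going by the name of the read-out) and lower numbers for less inhibition. For compound 1 the value < 10% is a limit of the assay, not a number. For compound 2 the value < 10% is likewise a limit. Among the compounds with values here, compound 3 gives 20% in this assay, the only number among the three.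

Compound 2 and compound 1 share one core and differ in a single place: phenyl in place of phenethyl on a saturated chain carbon bound to an amine nitrogen in a ring. The step that the two limits leave unreadable from compound 2 to compound 1 cannot be read, because both values sit at the limit of < 10% in this assay, at which 2 of the 3 values shown sit. Compound 3 carries a different core; the difference between the two cores is not broken down here.

Compound 4 `O=C(/C=C/c1cn([C@H]2C[C@H](C(=O)O)N(Cc3ccccc3)C2)nn1)NO` has not yet been measured. It is compound 3 with the same change that turns compound 2 into compound 1, made at the same place: phenyl in place of phenethyl on a saturated chain carbon bound to an amine nitrogen in a ring. The earlier step offers no size to lean on, since neither of its two values is a number. The step from compound 3 to compound 4 is therefore expected to be small, a number 5 percentage points lower from compound 3 to compound 4 (within the scatter). Compound 4 is expected to give 15% in this assay, with a likely spread from 3% to 32%. Within the data shown here, that expectation rests on compound 3, whose value 20% is the only number here, and on the unreadable step that the two limits leave unreadable from compound 2 to compound 1.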

Compound 4, a percentage reported as inhibition, at one concentration (the size of the read-out at that concentration, not a potency): 14%
Compound 4: the middle estimate sits 1 percentage points above what was measured; low and high end bracket the measured number.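

In this assay, exchanging 3-phenylpropyl for benzyl on the core of compound 3 gives a number 6 percentage points lower from compound 3 to compound 4 (within the scatter), so on this core the two compounds cannot be told apart. The same exchange links compound 2 and compound 1 on the other core, but that step cannot be read, because neither compound has a number to compare, only a limit of the assay: the limit of < 10% in this assay, at which 2 of the 4 values shown sit.

The change therefore has a readable size on one core only, which means this series does not show whether it carries over from one core to the other, and a single pair within the scatter establishes no trend for the change on any core.

Both chains shown, benzyl and 3-phenylpropyl, carry a bare phenyl ring, so it remains open what an amine on that ring, or a chain longer than 3-phenylpropyl, would give in this assay. As far as these compounds go, how the two cores compare with each other also remains open, as does how these compounds would rank at other concentrations, since a percentage at one concentration is not a potency.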